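Swapping the Aryl Group: Tolerance in HEL Cells

A few compounds are considered here, and "the series" means these few. Any claim that something is new, unique, unknown or untested is made for them only; others in the source may bear on it.

Measured so far:
- compound 1, `Cc1cc(-c2cccc(F)c2)c2ncc(CSCCc3ccccc3)n2c1`: 20 ug/mL
- compound 2, `COc1cccc(-c2cc(C)cn3c(CSCCc4ccccc4)cnc23)c1`: 100 ug/mL
- compound 3, `Cc1cc(-c2cccs2)c2ncc(CSCCc3ccccc3)n2c1`: 100 ug/mL

In an ADME assay on HEL cells (Homo sapiens) for cytotoxicity, with a stated time of 3 days (a higher number here means that more compound is tolerated, a lower number that less compound is tolerated), compound 3 gives 100 ug/mL, level with compound 2 at the digits shown, and the two together sit at the top of the three numbers; compound 1 lies furthest away, as the step of a 5.0-fold higher number from compound 1 to compound 3 (0.70 log units; beyond the scatter) shows. The change from compound 3 to compound 4, `COc1ccc(-c2cc(C)cn3c(CSCCc4ccccc4)cnc23)cc1`, is 4-methoxyphenyl in place of thiophen-2-yl on an aromatic carbon.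

Among the compounds with values here, two measured steps bear on this change. The step of no change at the digits printed from compound 2 to compound 3 (within the scatter) shows that thiophen-2-yl and 3-methoxyphenyl are tolerated alike, while the step of a 5.0-fold higher number from compound 1 to compound 3 (0.70 log units; beyond the scatter) shows that 3-fluorophenyl is tolerated less well. Within the data shown here, no measured pair compares a methoxyphenyl with the methoxy in one position against another, so the move of the methoxy group is untested here. A six-membered methoxy-bearing ring matched thiophen-2-yl once already, so the expected step of no change at the digits printed from compound 3 to compound 4 (within the scatter) is small, within the scatter. Compound 4 is therefore estimated at 100 ug/mL, with a range from 40 ug/mL to 200 ug/mL in this assay.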

Compound 4, minimum cytotoxic concentration: 20 ug/mL
For compound 4 the middle estimate is 5.0-fold (0.70 log units) above the measured one; the measured number lies below the stated range.
By their numbers in this assay, from the lowest: compounds 1 and 4 (each within the scatter of the next); then compounds 2 and 3 (each within the scatter of the next).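

In this assay, the exact methoxyphenyl group matters: 4-methoxyphenyl in place of 3-methoxyphenyl gives a 5.0-fold lower number from compound 2 to compound 4 (0.70 log units; beyond the scatter) and so does not keep the level of the 3-methoxyphenyl compound. The earlier match with thiophen-2-yl therefore holds for 3-methoxyphenyl only, as 4-methoxyphenyl in place of thiophen-2-yl gives a 5.0-fold lower number from compound 3 to compound 4 (0.70 log units; beyond the scatter) while 4-methoxyphenyl in place of 3-fluorophenyl gives no change at the digits printed from compound 1 to compound 4 (within the scatter) and so joins the lower pair. No measured evidence here explains why these groups part in this way.

Still open, as far as these compounds go, is whether the lower number follows the methoxy group itself or any group at that ring position, which 4-fluorophenyl or 4-methylphenyl could help to separate. An unsubstituted phenyl, 2-methoxyphenyl or furan-2-yl would also show how far this pattern extends.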